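This account rests on a few compounds, and the source may have more. Where it says the series, first, only, none or still open, it means among the compounds named here.

In a functional assay on MGC-803 cells (Homo sapiens) for inhibition, read by MTT assay, with a stated time of 72 h (a higher number here means a weaker inhibitor, a lower number a stronger inhibitor), compound 2 `COc1cc(/C=C/C(=O)c2ccc(OCCSC(=S)N3CCN(C)CC3)cc2)cc(OC)c1OC` gives 8280 nM, the lowest of the two numbers in hand. Compound 1 `O=C(/C=C/c1ccc(Cl)cc1)c1ccc(OCCCSC(=S)N2CCCC2)cc1` gives 34500 nM in this assay, a higher number beyond the scatter. Compound 3 `COc1cc(/C=C/C(=O)c2ccc(OCCCSC(=S)N3CCN(C)CC3)cc2)cc(OC)c1OC` is compound 2 with a group of 11 heavy atoms (7 carbon, 2 nitrogen, 2 sulfur; one six-membered non-aromatic ring with 2 hetero atoms) in place of a group of 10 heavy atoms (6 carbon, 2 nitrogen, 2 sulfur; one six-membered non-aromatic ring with 2 hetero atoms), on a saturated chain carbon, two bonds along the chain from an oxygen on an aromatic ring. For the measured compounds named here, no step between measured compounds isolates this change, so its size is not known from the data. The step from compound 2 to compound 3 is expected to stay within the usual scatter, with no clear direction. Compound 3 is therefore estimated at 9000 nM, with a range of 4000 nM to 20000 nM, which means an expected step of a 1.1-fold higher number from compound 2 to compound 3 (0.04 log units; within the scatter).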

Compound 3, half-maximal inhibitory concentration: 7370 nM
Compound 3: middle estimate off by 1.2-fold (0.09 log units), on the high side; measured number inside the range.
By their numbers in this assay, from the lowest: compounds 3 and 2 (each within the scatter of the next); then compound 1.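

In this assay, for the compounds shown here, the group of 11 heavy atoms in place of the group of 10 heavy atoms, on a saturated chain carbon, two bonds along the chain from an oxygen on an aromatic ring, gives a 1.1-fold lower number from compound 2 to compound 3 (0.05 log units; within the scatter), the first isolated step at this position. The two groups are not told apart here, with the rest of the structure held constant. No measured evidence bears on this result.

Going by these compounds, whether a longer chain with the same end ring would leave the number within the scatter remains open. Compound 1 differs from compound 3 in more than one place, so its separate contributions cannot be read.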